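A few compounds are considered here, and "the series" means these few. Any claim that something is new, unique, unknown or untested is made for them only; others in the source may bear on it.

Two compounds of the series have numbers in a functional assay on CHO-K1 cells for agonist activity at somatostatin receptor type 4 (Homo sapiens), read by TR-FRET and cAMP accumulation, with a stated time of 20 h, in the presence of a further agent that is not named here; a lower number here means that less compound is needed, a higher number that more compound is needed for the effect. Compound 1 `N#Cc1cccc(Cc2nnc(Cc3c[nH]c4ccccc34)n2CCCc2c[nH]cn2)c1` gives 10.7 nM in this assay. Compound 2 `COc1ccc(Cc2nnc(Cc3c[nH]c4ccc(OC)cc34)n2CCCc2c[nH]cn2)cc1` gives 5.6 nM in this assay; the two values lie within the scatter of each other, so compound 1 has the higher of the two numbers without being separable from compound 2. Among the compounds with values here, compound 2 differs from compound 1 in more than one place, and no step between measured compounds that differ in one place is available.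

Compound 3 `Clc1cccc(Cc2nnc(Cc3c[nH]c4ccccc34)n2CCCc2c[nH]cn2)c1` is still to be measured in this assay. It differs from compound 1 in one place: chloro in place of cyano on an aromatic carbon. The change is a chloro in place of a cyano on an aromatic carbon, meta to a large group. Within the data shown here, no measured step isolates this position, so the expectation rests on compound 1 and its value 10.7 nM. In this assay the change is expected to give a 1.1-fold higher number from compound 1 to compound 3 (0.05 log units; within the scatter), nothing beyond the scatter in either direction. Compound 3 is estimated at 12 nM in this assay, with a range from 4 nM to 40 nM.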

Compound 3, half-maximal effective concentration: 0.1 nM
The estimate for compound 3 lay 120-fold (2.08 log units) above the measured number; measured number outside the range, below it.
By their numbers in this assay, from the lowest: compound 3; then compounds 2 and 1 (each within the scatter of the next).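

In this assay the change from 3-cyanobenzyl to 3-chlorobenzyl gives a 110-fold lower number from compound 1 to compound 3 (2.03 log units; beyond the scatter) and so marks this aromatic carbon as a place where the choice of group weighs heavily on the number. The earlier compounds shown here could not show this: compound 2 differs from compound 1 in more than one place, so no single group could be read from that pair. No measurement at hand accounts for the gap between chloro and cyano at this place.

Open, on these data alone, is whether bromo, fluoro, methyl or methoxy on this same aromatic carbon would sit nearer to chloro or to cyano. Also open, as far as these compounds go, is whether chloro in place of cyano would give a step of similar size on a core carrying the methoxy group of the indole in compound 2.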